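Chlorophenyl for dimethylphenyl on the thiazoline series

The source may hold more compounds than are shown below. What is called first, only, known or untested is meant among the compounds shown, and "the series" means these compounds.

Two compounds have numbers in a functional assay on BGC-823 cells (Homo sapiens) for inhibition, read by CCK-8 assay, with a stated time of 48 h (a lower number here means a stronger inhibitor, a higher number a weaker inhibitor), so far. Compound 1 `O=C1CSC(N2N=C(c3ccc(Cl)cc3)CC2c2cccc3ccccc23)=N1` gives 16400 nM in this assay. Compound 2 `Cc1ccc(C2=NN(C3=NC(c4ccccc4)CS3)C(c3cccc4ccccc34)C2)cc1C` gives 8460 nM in this assay, which is within the scatter of the number for compound 1, so the two cannot be ranked. Compound 3 `Clc1ccc(C2=NN(C3=NC(c4ccccc4)CS3)C(c3cccc4ccccc34)C2)cc1` carries 4-chlorophenyl in place of 3,4-dimethylphenyl on a carbon with a double bond to nitrogen. Among the compounds with values here, no measured pair shows this exchange on this core, so the step from compound 2 is expected to be small, in no fixed direction, and likely within the scatter: a 1.2-fold higher number from compound 2 to compound 3 (0.07 log units; within the scatter). Compound 3 is therefore estimated at 10000 nM in this assay, with a range from 4000 nM to 25000 nM.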

Compound 3, half-maximal inhibitory concentration: 19600 nM
Estimate against measurement, compound 3: 2.0-fold (0.29 log units) below, within the range that was stated.
By their numbers in this assay, from the lowest: compounds 2, 1 and 3 (each within the scatter of the next, the first and the last beyond it).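

In this assay, 4-chlorophenyl in place of 3,4-dimethylphenyl on a carbon with a double bond to nitrogen gives a 2.3-fold higher number from compound 2 to compound 3 (0.36 log units; beyond the scatter), so this position does respond to the exchange, though the step is modest. With 4-chlorophenyl held constant, exchanging the group on the amine nitrogen in a ring gives a 1.2-fold higher number from compound 1 to compound 3 (0.08 log units; within the scatter), which does not separate the two groups. Nothing at hand explains either step. Open, as far as these compounds go, are how a phenyl ring carrying an amine or a carboxylic acid would read at this position, and whether the step seen here carries over to the core of compound 1.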